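Removing one fluorine from compound 3: what to expect

This account rests on a few compounds, and the source may have more. Where it says the series, first, only, none or still open, it means among the compounds named here.

compound 1 `Cc1ccc(/C=C/c2ccccc2F)cc1` gives 1400 nM in an assay on HepG2 cells for activation of nuclear factor erythroid 2-related factor 2 (Homo sapiens), read by a luciferase reporter, with a stated time of 5 h; a lower number here means that less compound is needed, a higher number that more compound is needed for the effect
compound 2 `Oc1ccc(/C=C/c2ccccc2F)cc1` gives 11400 nM in this assay
compound 3 `Fc1ccc(/C=C/c2ccccc2F)cc1F` gives > 15000 nM in this assay, which is a limit of the assay and not a number

Compound 3 thus stands at the limit (the limit of > 15000 nM in this assay, at which 1 of the 3 values shown sits), with no number of its own. Within the data shown here, compound 1 and compound 2 both carry numbers, and the step of an 8.1-fold higher number from compound 1 to compound 2 (0.91 log units; beyond the scatter) is the only measured step in the set.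

Compound 4 `Fc1ccc(/C=C/c2ccccc2F)cc1` differs from compound 3 by hydrogen in place of fluoro on an aromatic carbon. Among the measured compounds shown here, no measured step matches this change: the one step known concerns hydroxy in place of methyl, not hydrogen in place of fluoro, so it gives no direct size for the present step. With compound 3 at a limit only, the direction from compound 3 to compound 4 cannot be read from the data; the change is expected to move the number by an at least 3.0-fold lower number from compound 3 to compound 4 (0.47 log units; beyond the scatter) at most, and only as an estimate. Compound 4 is therefore expected to give about 5000 nM in this assay, within 1500 nM to 15000 nM.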

Compound 4, half-maximal effective concentration: 3600 nM
Beside the measured number, compound 4's estimate is 1.4-fold (0.14 log units) above it; the measured number falls inside the stated range.
By their numbers in this assay, from the lowest: compound 1; then compound 4; then compound 2. At a limit, above all of these: compound 3.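

Hydrogen in place of the fluoro group that stands ortho to a fluoro group gives a measurable result in this assay, with an at least 4.1-fold lower number from compound 3 to compound 4 (0.61 log units; beyond the scatter). The value of compound 3 is a limit of the assay and not a number: the limit of > 15000 nM in this assay, at which 1 of the 4 values shown sits.

The site that carries methyl or hydroxy also gains a third measured group, fluoro, with a 3.2-fold lower number from compound 2 to compound 4 (0.50 log units; beyond the scatter) and a 2.6-fold higher number from compound 1 to compound 4 (0.41 log units; beyond the scatter), which places fluoro in the middle of the three, each step beyond the scatter.

Going by these compounds, how an amine, a methoxy group or a carboxylic acid would rank at that site against methyl, fluoro and hydroxy remains open. Also open, on these data alone, is whether this order holds when the remaining fluoro group elsewhere on the shared core is replaced by hydrogen or chlorine.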